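Compound 4: an ethylpiperazine in place of a trimethylpiperazine

The source may report more compounds than this note shows. Statements on the series, on what has been measured and on what is new or still open speak of the compounds shown alone.

In an ADME assay on microsomes from liver (Homo sapiens) for metabolic stability, read by LC-MS, with a stated time of 10 min (on this read-out lower numbers stand for a less stable compound and higher numbers for a more stable compound), compound 1 `CN(C[C@H]1Cc2c(cccc2N2CCN(C3CC3)CC2)CN1)[C@H]1CCCc2cccnc21` gives 15.5%, compound 2 `CN(C[C@H]1Cc2c(cccc2N2CCN3CCC[C@@H]3C2)CN1)[C@H]1CCCc2cccnc21` gives 52.2% and compound 3 `C[C@@H]1CN(c2cccc3c2C[C@H](CN(C)[C@H]2CCCc4cccnc42)NC3)C[C@H](C)N1C` gives 24.6%. Compound 3 thus lies within the scatter of compound 1 and clearly under compound 2. Compound 4 `CCN1CCN(c2cccc3c2C[C@H](CN(C)[C@H]2CCCc4cccnc42)NC3)CC1`, not yet measured, places 4-ethylpiperazin-1-yl on the aromatic carbon that holds 3,4,5-trimethylpiperazin-1-yl in compound 3: 4-ethylpiperazin-1-yl in place of 3,4,5-trimethylpiperazin-1-yl on an aromatic carbon. Going by the values given here, two measured steps bear on this change. The step of a number 9.1 percentage points higher from compound 1 to compound 3 (within the scatter) joins two simple piperazines, while the modest step of a number 27.6 percentage points lower from compound 2 to compound 3 (beyond the scatter) involves the group with the additional five-membered ring. A change within the scatter is therefore expected, namely a number 4.6 percentage points lower from compound 3 to compound 4 (within the scatter). For compound 4 the estimated value is 20%, with an expected range from 9% to 36%.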

Compound 4, percent of the compound remaining: 0%
The estimate for compound 4 lay 20 percentage points above the measured number, and the stated range ends above it.
By their numbers in this assay, from the lowest: compound 4; then compounds 1 and 3 (each within the scatter of the next); then compound 2.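

In this assay, simple piperazines on this aromatic carbon no longer read alike: 4-ethylpiperazin-1-yl in place of 3,4,5-trimethylpiperazin-1-yl gives a number 24.6 percentage points lower from compound 3 to compound 4 (beyond the scatter), and ethyl in place of cyclopropyl on the ring amine nitrogen gives a number 15.5 percentage points lower from compound 1 to compound 4 (beyond the scatter). The group with the additional five-membered ring remains well apart, with a number 52.2 percentage points lower from compound 2 to compound 4 (beyond the scatter). Nothing measured here accounts for these steps. Going by these compounds, whether a methyl or isopropyl on that piperazine nitrogen, or a morpholine on this aromatic carbon, would read like compound 4 or like compound 1 stays open.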